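A few compounds are considered here, and "the series" means these few. Any claim that something is new, unique, unknown or untested is made for them only; others in the source may bear on it.

Measured so far in a functional assay on DU-145 cells (Homo sapiens) for antiproliferative activity, read by MTT assay, with a stated time of 48 h; a lower number here means a stronger inhibitor, a higher number a weaker inhibitor:

- compound 1 `C/C(=C\CC/C(C)=C/CC[C@@H]1[C@@]2(C)CCC(=O)C(C)(C)[C@H]2CC[C@@]1(C)O)CC/C=C(\C)C(=O)OCc1cn(-c2cccc(C)c2)nn1`: 137000 nM
- compound 2 `C/C(=C\CC/C(C)=C/CC[C@@H]1[C@@]2(C)CCC(=O)C(C)(C)[C@H]2CC[C@@]1(C)O)CC/C=C(\C)C(=O)OCc1cn(-c2ccccc2)nn1`: 95500 nM

Compound 2, at 95500 nM, lies within the usual scatter of compound 1, so these two numbers cannot be ranked. The next molecule, compound 3 `C/C(=C\CC/C(C)=C/CC[C@@H]1[C@@]2(C)CCC(=O)C(C)(C)[C@H]2CC[C@@]1(C)O)CC/C=C(\C)C(=O)OCc1cn(-c2ccccc2F)nn1`, keeps all of compound 2 except for one small edit, with phenyl becoming 2-fluorophenyl: fluoro in place of hydrogen on an aromatic carbon. The new fluoro sits ortho to a large group. For the measured compounds named here, only one measured step offers a guide, hydrogen in place of methyl on an aromatic carbon, and it is small: a 1.4-fold lower number from compound 1 to compound 2 (0.16 log units; within the scatter). Going by the values given here, that is thin evidence, and no fluoro compound has been measured yet. No shift beyond the scatter is therefore expected in this assay, in either direction. The estimated step is a 1.0-fold lower number from compound 2 to compound 3 (0.00 log units; within the scatter). Compound 3 is expected at about 95000 nM, with an estimated range of 48000 nM to 185000 nM.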

Compound 3, half-maximal inhibitory concentration: > 150000 nM
Compound 3: a limit, no number; the forecaster's own chance of this, stated with the estimate: 10%; at least 1.5-fold (0.19 log units) between middle value and limit.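

In this assay, compound 3 gives a limit of the assay and not a number: the limit of > 150000 nM in this assay, at which 1 of the 3 values shown sits. Fluoro in place of hydrogen on this aromatic carbon, ortho to a large group, therefore gives no measurable gain here, yet the size of the change stays hidden: an at least 1.5-fold higher number from compound 2 to compound 3 (0.19 log units; that floor lies within the scatter) is only a floor, and it lies within the scatter. The same holds for the swap of 3-methylphenyl for 2-fluorophenyl, an at least 1.0-fold higher number from compound 1 to compound 3 (0.03 log units; that floor lies within the scatter), so these compounds cannot be ranked.

Going by these compounds, the true value of compound 3 remains unknown, and so does whether the step from hydrogen to fluoro has any real effect. Also open, on these data alone, is how a chlorine atom, a methoxy group or an amine at this same place on the phenyl ring would read in this assay.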